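The source may report more compounds than this note shows. Statements on the series, on what has been measured and on what is new or still open speak of the compounds shown alone.

Three compounds have been examined so far in an assay on isolated protein for inhibition of Gonadotropin-releasing hormone receptor (Homo sapiens); on this read-out lower numbers stand for stronger inhibition and higher numbers for weaker inhibition. Compound 1, whose structure is `Cc1cccc(CSc2nc3cc(NC(=O)C4CC4)ccc3n2C(C)C)c1`, gives 6500 nM in this assay. Compound 2, with the structure `COc1ccc(C(C)=O)cc1CSc1nc2cc(NC(=O)C3CC3)ccc2n1C(C)C`, gives 260 nM in this assay. Compound 3, built as `CCCCCn1c(SCc2cc([N+](=O)[O-])ccc2OC)nc2cc(NC(=O)NC(C)(C)C)ccc21`, gives 210 nM in this assay. Among these three numbers compound 3 has the lowest, but its gap to compound 2 is small enough to sit within the usual scatter of repeated measurements, so the two cannot be told apart; only compound 1 stands clearly apart from it, with a much higher number.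

The next compound, compound 4, has the structure `COc1ccc([N+](=O)[O-])cc1CSc1nc2cc(NC(=O)NC(C)(C)C)ccc2n1-c1ccccc1`. It differs from compound 3 in one place: phenyl in place of pentyl on an aromatic nitrogen. Among the measured compounds shown here, no measured pair among the earlier compounds shows this same exchange, so nothing in the existing numbers tells how large a shift it brings. Because compound 3 already sits at 210 nM, and the rest of the molecule is kept unchanged, the expectation is a step no larger than the ordinary scatter, with no clear direction. The estimated step is therefore a 1.4-fold higher number from compound 3 to compound 4 (0.15 log units; within the scatter), and the expected value for compound 4 is 300 nM, within a range from 60 nM to 1500 nM.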

Compound 4, half-maximal inhibitory concentration: 350 nM
Beside the measured number, compound 4's estimate is 1.2-fold (0.07 log units) below it; low and high end bracket the measured number.
By their numbers in this assay, from the lowest: compounds 3, 2 and 4 (each within the scatter of the next); then compound 1.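

In this assay, putting phenyl in place of pentyl on the aromatic nitrogen gives a 1.7-fold higher number from compound 3 to compound 4 (0.22 log units; within the scatter), so the two groups cannot be told apart on this read-out. Among the compounds shown here, this is the first direct reading at this position, as no earlier pair of compounds differed here alone, and it shows that an open chain without a ring and a six-membered aromatic ring of carbon only can occupy this nitrogen with no measurable change in the number. Nothing available explains why these two quite different groups read alike.

On these data alone, one exchange cannot show how much this position matters, so it remains open whether a much smaller group such as methyl, a benzyl group, or a chain ending in an amine or a carboxylic acid would move the number beyond the scatter. As far as these compounds go, it is also open whether the same exchange would read alike on a molecule with a different group elsewhere on the shared core, such as the cyclopropyl amide found in compound 1 and compound 2.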